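This account rests on a few compounds, and the source may have more. Where it says the series, first, only, none or still open, it means among the compounds named here.

Working notes on the series:

- compound 1 `N#Cc1ccc(/C=C/S(=O)(=O)Cc2ccc(Nc3ncnc4ccccc34)cc2)cc1`: > 100000 nM (a limit of the assay)
- compound 2 `O=S(=O)(/C=C/c1ccc(Cl)c(Cl)c1)Cc1ccc(Nc2ncnc3ccccc23)cc1`: 11000 nM
- compound 3 `O=S(=O)(/C=C/c1ccc(C(F)(F)F)cc1F)Cc1ccc(Nc2ncnc3ccccc23)cc1`: 100000 nM
- compound 4 `O=S(=O)(/C=C/c1ccc(Cl)c(Cl)c1)Cc1ccc(Nc2ncnc3ccc(Br)cc23)cc1`: not yet measured

All values come from a functional assay on U-251 cells (Homo sapiens); on this read-out lower numbers stand for stronger inhibition of growth and higher numbers for weaker inhibition of growth. Among the values that are numbers, compound 2 at 11000 nM is the lower of the two. The value for compound 1 is only a limit (the limit of > 100000 nM in this assay, at which 1 of the 3 values shown sits).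

Compound 4 differs from compound 2 by bromo in place of hydrogen on an aromatic carbon, on the shared core. The measured steps, an at least 9.0-fold lower number from compound 1 to compound 2 (0.95 log units; beyond the scatter) and a 9.1-fold higher number from compound 2 to compound 3 (0.96 log units; beyond the scatter), all change the aryl group on the chain and none changes the core. They show that compound 2 can move by that size, but they give no direction for this change, so a shift beyond the scatter is not expected as the central case.

The expected step is a 1.2-fold lower number from compound 2 to compound 4 (0.09 log units; within the scatter). For compound 4 the estimated value is 9000 nM, with an expected range of 2000 nM to 40000 nM.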

Compound 4, concentration for 50% growth inhibition: > 100000 nM
Compound 4: no number, only a limit; the forecaster's own chance of this, stated with the estimate: 8%; middle value at least 11-fold (1.04 log units) away from the limit.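

In this assay, for the compounds shown here, bromo in place of hydrogen on an aromatic carbon of the shared core gives an at least 9.0-fold higher number from compound 2 to compound 4 (0.95 log units; beyond the scatter) and so shows what the earlier steps on the aryl group could not: a change on the core alone can move the read-out beyond the scatter, here towards weaker inhibition of growth. Compound 4 gives > 100000 nM as a limit of the assay, so the full size of this step stays open: the limit of > 100000 nM in this assay, at which 2 of the 4 values shown sit.

Open, on these data alone, is whether an amine or a methoxy group on this aromatic carbon would give the same result. Also open, as far as these compounds go, is whether bromo there behaves alike with another aryl group on the chain.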